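The compounds below may be only part of what the source reports. "The series", "measured", "known", "first", "only" and "open" are said of these compounds alone.

Compound 1 `COc1ccc(C(=O)Nc2cccc(-c3oc4cc(-c5ccc(F)cc5)ccc4c(=O)c3O)c2)cc1` is one of three closely related compounds measured in a functional assay on MDA-MB-231 cells (Homo sapiens) for antiproliferative activity, read by CCK-8 assay, with a stated time of 72 h (a higher number here means a weaker inhibitor, a lower number a stronger inhibitor), where compound 1 gives 16500 nM. Compound 2 `COc1ccccc1C(=O)Nc1cccc(-c2oc3cc(-c4ccc(F)cc4)ccc3c(=O)c2O)c1` differs from it only in the group on the carbonyl carbon; in this assay compound 2 gives 5110 nM, and the step is a 3.2-fold lower number from compound 1 to compound 2 (0.51 log units; beyond the scatter). Compound 3 `O=C(Nc1cccc(-c2oc3cc(-c4ccc(F)cc4)ccc3c(=O)c2O)c1)c1ccc(Br)cc1` carries yet another group at that carbon and gives 24900 nM in this assay, a step of a 1.5-fold higher number from compound 1 to compound 3 (0.18 log units; within the scatter) from compound 1, while from compound 2 the step is a 4.9-fold higher number from compound 2 to compound 3 (0.69 log units; beyond the scatter). Among these three numbers compound 1 therefore stands second highest: compound 3 sits within the scatter of it, and only compound 2 lies clearly lower.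

Compound 4 `Cc1cccc(C(=O)Nc2cccc(-c3oc4cc(-c5ccc(F)cc5)ccc4c(=O)c3O)c2)c1` has not yet been measured. Its difference from compound 1 is 3-methylphenyl in place of 4-methoxyphenyl on a carbonyl carbon. Among the measured compounds shown here, no measured step exchanges exactly these two groups. The two steps that bear on the change both alter the group on the carbonyl carbon: a 3.2-fold lower number from compound 1 to compound 2 (0.51 log units; beyond the scatter) lowered the number beyond the scatter, while a 1.5-fold higher number from compound 1 to compound 3 (0.18 log units; within the scatter) stayed within it. Neither settles the direction for compound 4. A step of a 1.4-fold lower number from compound 1 to compound 4 (0.14 log units; within the scatter) is expected, modest and close to the scatter. Compound 4 is therefore estimated at 12000 nM in this assay, with a range from 4000 nM to 40000 nM.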

Compound 4, half-maximal inhibitory concentration: 2840 nM
Estimate against measurement, compound 4: 4.2-fold (0.63 log units) above, outside the stated range (below it).
By their numbers in this assay, from the lowest: compounds 4 and 2 (each within the scatter of the next); then compounds 1 and 3 (each within the scatter of the next).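

In this assay, 3-methylphenyl on the carbonyl carbon gives a 5.8-fold lower number from compound 1 to compound 4 (0.76 log units; beyond the scatter) and an 8.8-fold lower number from compound 3 to compound 4 (0.94 log units; beyond the scatter), so a clear drop at this position does not need the methoxy group of compound 2: the entering group holds carbon only. Its step against the earlier best compound is a 1.8-fold lower number from compound 2 to compound 4 (0.26 log units; within the scatter), so 3-methylphenyl and 2-methoxyphenyl cannot be told apart in this assay. Across these four compounds, the 4-methoxyphenyl and 4-bromophenyl groups of compound 1 and compound 3 give the higher numbers, the 2-methoxyphenyl and 3-methylphenyl groups of compound 2 and compound 4 give the lower numbers, and no compound shown goes against this split.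

No measurement offered here explains why these groups differ. Still open, from the compounds shown here alone, is whether the place of the substituent on the ring or its kind decides the result, which a 4-methylphenyl or a 3-methoxyphenyl group would help to separate, and whether a ring carrying an amine or a carboxylic acid would fit the same split.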